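Cytotoxicity of a Third Aryl Variant on a Shared Core

The compounds below may be only part of what the source reports. "The series", "measured", "known", "first", "only" and "open" are said of these compounds alone.

Compound 1 `Nc1ccc(-c2nnc(SC3=CS(=O)(=O)c4ccccc43)o2)cc1`: 4000 nM
Compound 2 `COc1ccccc1-c1nnc(SC2=CS(=O)(=O)c3ccccc32)o1`: 3000 nM

In an ADME assay on HEK293 cells (Homo sapiens) for cytotoxicity, read by fluorescence and resazurin assay, with a stated time of 24 h (a higher number here means that more compound is tolerated, a lower number that less compound is tolerated), compound 1 gives 4000 nM, the higher of the two numbers recorded so far. Going by the values given here, its only neighbour is compound 2, which in this assay gives 3000 nM. Among the compounds with values here, the single measured step, a 1.3-fold lower number from compound 1 to compound 2 (0.12 log units; within the scatter), exchanges the aryl group on the shared core and leaves the read-out essentially unchanged.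

Compound 3 `O=S1(=O)C=C(Sc2nnc(-c3cccc(Cl)c3)o2)c2ccccc21` has not yet been measured. Relative to compound 1 it differs in one place: 3-chlorophenyl in place of 4-aminophenyl on an aromatic carbon. This is the same kind of exchange as in the step from compound 1 to compound 2, an aryl group replaced by another aryl group on the same carbon of the core. That step bears directly on the present one, and it was within the scatter. Within the data shown here, no other step is available, and nothing in the two measured compounds points to a direction.

Compound 3 is therefore expected to sit close to compound 1, with a step of a 1.1-fold lower number from compound 1 to compound 3 (0.06 log units; within the scatter) that stays within the scatter. The estimate for compound 3 in this assay is 3500 nM, with a range from 1500 nM to 8000 nM.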

Compound 3, half-maximal cytotoxic concentration: 6000 nM
Beside the measured number, compound 3's estimate is 1.7-fold (0.23 log units) below it; the measured number falls inside the stated range.
By their numbers in this assay, from the lowest: compounds 2, 1 and 3 (each within the scatter of the next).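

In this assay the exchange of 4-aminophenyl for 3-chlorophenyl gives a 1.5-fold higher number from compound 1 to compound 3 (0.18 log units; within the scatter) and so stays within the scatter, even though the entering group carries chlorine in place of nitrogen and has 0 hydrogen-bond donors and 0 hydrogen-bond acceptors where the leaving group has 1 of each. The exchange of 2-methoxyphenyl for 3-chlorophenyl gives a 2.0-fold higher number from compound 2 to compound 3 (0.30 log units; within the scatter) and likewise marks no real difference. Going by these compounds alone, with three aryl groups now seen on this aromatic carbon of the five-membered aromatic ring, differing in substituent and in where it sits on the phenyl ring, no step has left the scatter, which holds for these three compounds only. No measurement at hand bears on the reason for this.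

The compounds shown leave open whether something other than a substituted phenyl on this carbon, such as a carboxylic acid, a pyridine ring or a longer alkyl chain, would move the number beyond the scatter. On these data alone, all three also share the same core, so what this assay would report for a change there remains unknown.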